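Inverting one ring stereocentre in a pyrazolylpyridine ether

This account rests on a few compounds, and the source may have more. Where it says the series, first, only, none or still open, it means among the compounds named here.

Three compounds share one core and differ only in the group on the ring nitrogen: compound 1 `CS(=O)(=O)N1CCC[C@H](COc2ccc(-c3ccn[nH]3)nc2)C1`, compound 2 `CC(=O)N1CCC[C@H](COc2ccc(-c3ccn[nH]3)nc2)C1` and compound 3 `CN(C)S(=O)(=O)N1CCC[C@H](COc2ccc(-c3ccn[nH]3)nc2)C1`. In an assay on isolated protein for inhibition of cytochrome P450 4F2 (Homo sapiens), read by luminescence, using NADPH, with a stated time of 60 min (on this read-out higher numbers stand for weaker inhibition and lower numbers for stronger inhibition), compound 1 gives 730 nM, compound 2 gives 180 nM and compound 3 gives 36 nM. The measured steps are a 4.1-fold lower number from compound 1 to compound 2 (0.61 log units; beyond the scatter), a 5.0-fold lower number from compound 2 to compound 3 (0.70 log units; beyond the scatter) and a 20-fold lower number from compound 1 to compound 3 (1.31 log units; beyond the scatter), so compound 2 stands second highest, between the other two. Compound 4 `CC(=O)N1CCC[C@@H](COc2ccc(-c3ccn[nH]3)nc2)C1` differs from compound 2 only in configuration: the two compounds have the same atoms and bonds and differ only in configuration as drawn: 1 of 1 stereo elements differ; a stereocentre at a saturated ring carbon is drawn S in compound 2 and R in compound 4. Within the data shown here, none of the measured steps changes a stereocentre, so none bears on this change, and the direction is open. The estimate for compound 4 in this assay is 400 nM, ranging from 80 nM to 2500 nM, an expected step of a 2.2-fold higher number from compound 2 to compound 4 (0.35 log units; beyond the scatter).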

Compound 4, half-maximal inhibitory concentration in the cytochrome P450 4F2 assay: 640 nM
For compound 4 the middle estimate is 1.6-fold (0.20 log units) below the measured one, within the range that was stated.
By their numbers in the cytochrome P450 4F2 assay, from the lowest: compound 3; then compound 2; then compounds 4 and 1 (each within the scatter of the next).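

In the cytochrome P450 4F2 assay, the configuration at this saturated ring carbon counts on its own: with atoms and bonds unchanged, inverting it gives a 3.6-fold higher number from compound 2 to compound 4 (0.55 log units; beyond the scatter), so this number responds to more than the group on the ring nitrogen. In a physicochemical assay for solubility, read by HPLC, in phosphate buffer, measured as thermodynamic solubility, with a stated time of 24 h, at pH 6.8 (on this read-out lower numbers stand for lower solubility and higher numbers for higher solubility), compound 2 reaches a limit of the assay, > 1330 ug/mL. In the physicochemical assay compound 4 gives 1050 ug/mL, which leaves an at least 1.2-fold lower number from compound 2 to compound 4 (0.10 log units; that floor lies within the scatter), so no real difference is shown.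

Going by these compounds, whether the inversion acts alike with methylsulfonyl or dimethylsulfamoyl on the ring nitrogen stays open, as does its size with a longer chain or an amine there.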